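Chloro for Bromo on the Fused Ring of Compound 2

The compounds below may be only part of what the source reports. "The series", "measured", "known", "first", "only" and "open" are said of these compounds alone.

Among the measured compounds shown here, compound 2 `COc1ccc(C2=NN(C3=NC(=O)/C(=C4\C(=O)Nc5ccc(Br)cc54)S3)C(c3ccc(Cl)cc3)C2)cc1` stands lowest of the two numbers so far in a functional assay on cells (Cancer cell lines, Homo sapiens) for cytotoxicity, read by sulforhodamine B assay, with a stated time of 48 h (a higher number here means a weaker inhibitor of growth, a lower number a stronger inhibitor of growth), where compound 2 gives 1480 nM. For the measured compounds named here, its only neighbour, compound 1 `COc1ccc(C2=NN(C3=NC(=O)/C(=C4\C(=O)Nc5ccccc54)S3)C(c3ccc(Cl)cc3)C2)cc1`, gives 100000 nM, so that a 68-fold lower number from compound 1 to compound 2 (1.83 log units; beyond the scatter) with bromo in place of hydrogen. Compound 3 `COc1ccc(C2=NN(C3=NC(=O)/C(=C4\C(=O)Nc5ccc(Cl)cc54)S3)C(c3ccc(Cl)cc3)C2)cc1` differs from compound 2 by chloro in place of bromo on an aromatic carbon. No measured step exchanges one of these two groups for the other; the single step shown concerns adding bromo, and it was large. An exchange of chloro for bromo is expected to shift this assay little, at most modestly toward a higher number: a 1.4-fold higher number from compound 2 to compound 3 (0.13 log units; within the scatter). Compound 3 is therefore estimated at 2000 nM, within 700 nM to 6000 nM.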

Compound 3, concentration for total growth inhibition: 430 nM
Beside the measured number, compound 3's estimate is 4.7-fold (0.67 log units) above it; measured number below the stated range.
By their numbers in this assay, from the lowest: compound 3; then compound 2; then compound 1.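

In this assay the choice of halogen at this position counts, not only its presence: there is a 3.4-fold lower number from compound 2 to compound 3 (0.54 log units; beyond the scatter) on exchanging bromo for chloro. Set against hydrogen, chloro gives a 230-fold lower number from compound 1 to compound 3 (2.37 log units; beyond the scatter) and so exceeds the step seen for bromo. Nothing available explains this difference between the two halogens.

The compounds shown leave open how fluoro, a methoxy group or an amine would fare on this aromatic carbon. They also leave open whether the gain from chloro holds when the rest of the shared core changes.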